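A Second Methoxy on Compound 3

This account rests on a few compounds, and the source may have more. Where it says the series, first, only, none or still open, it means among the compounds named here.

In an ADME assay on MCF7 cells (Homo sapiens) for cytotoxicity, with a stated time of 72 h (a lower number here means a stronger inhibitor, a higher number a weaker inhibitor), compound 1 `COc1cccc(CNc2ncnc3c2ncn3C2CCCCO2)c1` gives 97000 nM. Compound 2 `COc1cc(CNc2ncnc3c2ncn3C2CCCCO2)cc(OC)c1` carries an extra methoxy group on the aromatic ring of compound 1. Compound 2 reads > 100000 nM, which is a limit and not a number. Compound 3 `COc1cccc(CNc2ncnc3c2ncn3C2CCCO2)c1` keeps the ring of compound 1 but has oxolan-2-yl in place of oxan-2-yl on an aromatic nitrogen. Compound 3 reads > 100000 nM, again a limit and not a number. Compound 3 therefore stands at the limit of > 100000 nM in this assay, at which 2 of the 3 values shown sit.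

Compound 4 `COc1cc(CNc2ncnc3c2ncn3C2CCCO2)cc(OC)c1` is compound 3 with one change: methoxy in place of hydrogen on an aromatic carbon. The same swap, methoxy in place of hydrogen on an aromatic carbon, has been measured once, as an at least 1.0-fold higher number from compound 1 to compound 2 (0.01 log units; that floor lies within the scatter). The other measured step, the ring swap, is an at least 1.0-fold higher number from compound 1 to compound 3 (0.01 log units; that floor lies within the scatter). Both steps give only a floor, so neither shows a change beyond the scatter. Among the compounds with values here, with an at least 1.0-fold higher number from compound 1 to compound 2 (0.01 log units; that floor lies within the scatter) as the closest precedent, no step beyond the scatter is expected in this assay. The step expected here is a step that the limit leaves unreadable from compound 3 to compound 4. For compound 4 the estimated value is 120000 nM, with an expected range from 70000 nM to 200000 nM, and the reading will most probably be only a limit.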

Compound 4, half-maximal inhibitory concentration: > 100000 nM
Compound 4: a limit, no number; the forecaster's own chance of this, stated with the estimate: 85%; the middle value is on the limit's open side.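

Compound 4 gives only a limit in this assay, and so do compound 2 and compound 3, so neither the methoxy step from compound 3 nor the ring step from compound 2 can be read. The compounds shown leave open how these three compare with one another, because their readings stop at one limit: the limit of > 100000 nM in this assay, at which 3 of the 4 values shown sit.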